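Swapping dichlorophenyl patterns at the benzyl ether of compound 2

The compounds below may be only part of what the source reports. "The series", "measured", "known", "first", "only" and "open" are said of these compounds alone.

Of the compounds shown here, two have been measured in an assay on CHO cells for binding affinity to metabotropic glutamate receptor 2 (Rattus norvegicus); on this read-out higher numbers stand for weaker inhibition and lower numbers for stronger inhibition. Compound 1, `N[C@]1(C(=O)O)[C@H]2[C@@H](C[C@H]1OCc1cccc(Cl)c1)[C@]2(F)C(=O)O`, gives 3.28 nM in this assay. Compound 2, `N[C@]1(C(=O)O)[C@H]2[C@@H](C[C@H]1OCc1ccc(Cl)cc1Cl)[C@]2(F)C(=O)O`, gives 3.89 nM in this assay. Compound 2 carries the higher of the two numbers, but the gap to compound 1 is within the scatter, so the two cannot be told apart.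

Compound 3, `N[C@]1(C(=O)O)[C@H]2[C@@H](C[C@H]1OCc1cc(Cl)ccc1Cl)[C@]2(F)C(=O)O`, is not yet measured. It differs from compound 2 by 2,5-dichlorophenyl in place of 2,4-dichlorophenyl on a saturated chain carbon bound to an oxygen on a saturated carbon. Among the measured compounds shown here, the only measured step that bears on this change is a 1.2-fold higher number from compound 1 to compound 2 (0.07 log units; within the scatter), which also exchanged one chlorine pattern on the phenyl ring for another and stayed within the scatter. On that basis no step beyond the scatter is expected in this assay; the expected step is a 1.0-fold higher number from compound 2 to compound 3 (0.01 log units; within the scatter). Compound 3 is estimated at 4 nM, with a range from 1.5 nM to 12 nM.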

Compound 3, inhibition constant: 11.8 nM
Compound 3: middle estimate off by 3.0-fold (0.47 log units), on the low side, within the range that was stated.
By their numbers in this assay, from the lowest: compounds 1 and 2 (each within the scatter of the next); then compound 3.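

In this assay the chlorine arrangement on this ring can matter: a 3.0-fold higher number from compound 2 to compound 3 (0.48 log units; beyond the scatter) comes from a change that keeps the same atoms and only joins them differently. Compound 3 also separates from its one-chlorine relative, with a 3.6-fold higher number from compound 1 to compound 3 (0.56 log units; beyond the scatter) for chloro in place of hydrogen on an aromatic carbon, yet a second chlorine does not give such a step in every case, as compound 2 goes against that pattern by staying within the scatter of compound 1. Nothing available here explains why the 2,5-dichlorophenyl group differs from the 2,4-dichlorophenyl group.

Still open, from the compounds shown here alone, is whether a bromine or a methoxy group in place of these chlorines would show the same dependence on ring pattern.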